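Removing one 3-methylbut-2-en-1-yl group from compound 3

The source may hold more compounds than are shown below. What is called first, only, known or untested is meant among the compounds shown, and "the series" means these compounds.

Compound 1 `COc1cc(O)c(C(=O)/C=C/c2cccc(Cl)c2Cl)c(OC)c1` gives 2700 nM in a functional assay on HCT-116 cells (Homo sapiens) for antiproliferative activity, read by sulforhodamine B assay, with a stated time of 48 h (a lower number here means a stronger inhibitor, a higher number a weaker inhibitor), and compound 2 `COc1cc(O)c(C(=O)/C=C/c2cccc(OC)c2OC)c(OC)c1` gives 3500 nM there, two values within the usual scatter of each other. Compound 3 `COc1cccc(/C=C/C(=O)c2c(O)c(CC=C(C)C)c(OC)c(CC=C(C)C)c2OC)c1OC` at 15300 nM has the highest number of the three, beyond the scatter from both others. Compound 4 `COc1cc(O)c(C(=O)/C=C/c2cccc(OC)c2OC)c(OC)c1CC=C(C)C` carries hydrogen in place of 3-methylbut-2-en-1-yl on an aromatic carbon of compound 3, a change counted as hydrogen in place of 3-methylbut-2-en-1-yl on an aromatic carbon in full. Within the data shown here, no measured pair shows this change alone, so its size remains uncertain. Among the measured compounds shown here, with compound 3 at 15300 nM the highest number so far, a modest step towards a lower number is expected in this assay for compound 4. The estimated change is a 2.2-fold lower number from compound 3 to compound 4 (0.34 log units; beyond the scatter) as a rough guide. Compound 4 is estimated at 7000 nM with an expected range from 2500 nM to 18000 nM in this measurement.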

Compound 4, half-maximal inhibitory concentration: 29500 nM
Compound 4: the middle estimate sits 4.2-fold (0.62 log units) below what was measured, outside the stated range (above it).
By their numbers in this assay, from the lowest: compounds 1 and 2 (each within the scatter of the next); then compounds 3 and 4 (each within the scatter of the next).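

On the aromatic carbon ortho to a hydroxy group and ortho to a methoxy group, hydrogen in place of 3-methylbut-2-en-1-yl gives no readable change in this assay (a 1.9-fold higher number from compound 3 to compound 4 (0.29 log units; within the scatter)). The clear shift comes with the 3-methylbut-2-en-1-yl group that compound 4 keeps (an 8.4-fold higher number from compound 2 to compound 4 (0.93 log units; beyond the scatter)), so the high numbers already appear with one such group, and a second adds nothing readable. Nothing available explains this. On these data alone, whether a methyl group, a longer chain or an amine on this carbon would give a lower number remains open.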